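The source may report more compounds than this note shows. Statements on the series, on what has been measured and on what is new or still open speak of the compounds shown alone.

Compound 1, `COc1ccc(/C=C2\CCC/C(=C\c3cccc(OC)c3OC)C2=O)cc1`, gives in a functional assay on A549 cells (Homo sapiens) for cytotoxicity, read by MTT assay, with a stated time of 72 h (on this read-out higher numbers stand for weaker inhibition and lower numbers for stronger inhibition), a value of > 20000 nM, which is a limit of the assay and not a number. Compound 2, `COc1ccc(/C=C2\CCC/C(=C\c3ccccc3Cl)C2=O)cc1OC`, gives in this assay a value of > 20000 nM, again a limit of the assay rather than a measured number.

Among the measured compounds shown here, compound 2 thus stands only at a limit, and the one other value shown is a limit too; both sit at the limit of > 20000 nM in this assay, at which 2 of the 2 values shown sit. Compound 3, `COc1ccc(/C=C2\CCC/C(=C\c3cccc(Cl)c3Cl)C2=O)cc1OC`, has not yet been tested in this assay. It differs from compound 2 by chloro in place of hydrogen on an aromatic carbon. For the measured compounds named here, no step between measured compounds is known here, so there is nothing to set a size against. With both known values resting at a limit, the expected step is a step that the limit leaves unreadable from compound 2 to compound 3, that is, no movement beyond the scatter in either direction. Compound 3 is therefore expected to give 30000 nM, within a range from 8000 nM to 100000 nM, most probably reported once more only as a limit.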

Compound 3, half-maximal inhibitory concentration: > 20000 nM
Compound 3: no number, only a limit; the forecaster's own chance of this, stated with the estimate: 75%; the middle value lies beyond the limit too.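

No step can be read from compound 2 to compound 3, since neither gives a number, only a limit of the assay: the limit of > 20000 nM in this assay, at which 3 of the 3 values shown sit. As far as these compounds go, whether chloro in place of hydrogen changes anything at all, and what change to the shared core would give a real number in this assay, stays open.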